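The source may report more compounds than this note shows. Statements on the series, on what has been measured and on what is new or still open speak of the compounds shown alone.

Measured so far in a functional assay on RKO cells (Homo sapiens) for cytotoxicity, read by MTT assay, with a stated time of 48 h; a higher number here means a weaker inhibitor, a lower number a stronger inhibitor:
- compound 1 `CCCCOc1ccc2c(Cl)ccnc2c1` gives 3050 nM
- compound 2 `Clc1ccnc2cc(OCCCc3ccccc3)ccc12` gives 1420 nM
- compound 3 `Clc1ccnc2cc(OCCc3ccccc3)ccc12` gives 2560 nM

Compound 1 has the highest of the three numbers, although its gap to compound 3 is within the scatter; only compound 2 sits clearly apart, by a 2.1-fold lower number from compound 1 to compound 2 (0.33 log units; beyond the scatter). Compound 4 `CC(C)Oc1ccc2c(Cl)ccnc2c1` differs from compound 1 by isopropyl in place of butyl on an oxygen on an aromatic ring.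

The three measured steps all alter the far end of the chain: a phenyl entering in place of methyl gave a 2.1-fold lower number from compound 1 to compound 2 (0.33 log units; beyond the scatter), in place of ethyl a 1.2-fold lower number from compound 1 to compound 3 (0.08 log units; within the scatter), and in place of benzyl a 1.8-fold higher number from compound 2 to compound 3 (0.26 log units; within the scatter). None removes carbons from the chain as the step to compound 4 does, so they only hint that changes on this chain stay small. For compound 4 the expected step is a 1.3-fold higher number from compound 1 to compound 4 (0.12 log units; within the scatter), with no clear direction beyond the scatter. Compound 4 is therefore estimated at 4000 nM, within 1500 nM to 10000 nM.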

Compound 4, half-maximal inhibitory concentration: 2690 nM
Compound 4: the middle estimate sits 1.5-fold (0.17 log units) above what was measured, and the stated range covers the measured number.
By their numbers in this assay, from the lowest: compounds 2, 3, 4 and 1 (each within the scatter of the next, the first and the last beyond it).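

Replacing butyl with isopropyl on the oxygen gives a 1.1-fold lower number from compound 1 to compound 4 (0.05 log units; within the scatter) in this assay and is the first step shown that shortens the alkyl chain itself instead of altering its far end. At this position, the branched isopropyl group leaves the number within the scatter of the butyl compound. Nothing measured here bears on the reason for this result. As far as these compounds go, it remains open whether an amine or a carboxylic acid on the chain would shift the number beyond the scatter. A methyl group on the oxygen also remains untested among the compounds shown.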